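Cyano for trifluoromethyl in a cytotoxicity test

This account rests on a few compounds, and the source may have more. Where it says the series, first, only, none or still open, it means among the compounds named here.

Going by the values given here, in an ADME assay on MT4 cells (Homo sapiens) for cytotoxicity, read by MTT assay, with a stated time of 5 days (on this read-out higher numbers stand for lower toxicity in this test and lower numbers for higher toxicity in this test), compound 2 (`COc1cc2nc([S+]([O-])CC(=O)Nc3ccc(C(F)(F)F)cc3)nc(Nc3c(Cl)cc(/C=C/C#N)cc3Cl)c2cc1OC`) gives 22000 nM as the lowest of the two numbers so far, and compound 1 (`COc1cc2nc([S+]([O-])CC(=O)Nc3ccc([N+](=O)[O-])cc3)nc(Nc3c(Cl)cc(/C=C/C#N)cc3Cl)c2cc1OC`) gives 92800 nM as the other. Compound 3 (`COc1cc2nc([S+]([O-])CC(=O)Nc3ccc(C#N)cc3)nc(Nc3c(Cl)cc(/C=C/C#N)cc3Cl)c2cc1OC`) carries cyano in place of trifluoromethyl on an aromatic carbon and is otherwise the same as compound 2. Among the compounds with values here, the only measured step at this place is a 4.2-fold lower number from compound 1 to compound 2 (0.63 log units; beyond the scatter) and it was modest, with trifluoromethyl replacing nitro. Within the data shown here, no cyano compound has been measured, so a similarly modest rise is expected, an estimated 2.0-fold higher number from compound 2 to compound 3 (0.31 log units; beyond the scatter) at most roughly that size. In this assay compound 3 is estimated at 45000 nM with 17000 nM to 110000 nM as the expected range.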

Compound 3, half-maximal cytotoxic concentration: >= 188000 nM
Compound 3: only a limit was reported; the forecaster's own chance of this, stated with the estimate: 15%; middle value at least 4.1-fold (0.62 log units) away from the limit.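

Compound 3 gives a limit rather than a number in this assay: the limit of >= 188000 nM in this assay, at which 1 of the 3 values shown sits. Putting cyano in place of trifluoromethyl gives an at least 8.5-fold higher number from compound 2 to compound 3 (0.93 log units; beyond the scatter), so among these three groups on this aromatic carbon, trifluoromethyl now stands out with the lowest number and the highest toxicity in this test. Cyano in place of nitro gives an at least 2.0-fold higher number from compound 1 to compound 3 (0.30 log units; that floor lies within the scatter), so these two groups cannot be put in order.

As far as these compounds go, it remains open how far the number for compound 3 lies past its limit. From the compounds shown here alone, how an amine or a carboxylic acid at this place would read also remains open.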